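Short half-lives and one exception in the series

The compounds below may be only part of what the source reports. "The series", "measured", "known", "first", "only" and "open" are said of these compounds alone.

Measured in an ADME assay on microsomes from liver (Rattus norvegicus) for metabolic stability; a lower number here means that the compound disappears faster, a higher number that the compound lasts longer:
- compound 1 `CC(C)C(c1ccc(-c2ccc3cccc(F)c3c2)[nH]c1=O)N1CCCCS1(=O)=O`: 0.07 h
- compound 2 `CC(C)C(Cc1noc(=O)[nH]1)c1ccc(-c2ccc3cccc(F)c3c2)[nH]c1=O`: > 3 h (a limit of the assay)
- compound 3 `CC(C)C(c1ncc[nH]1)c1ccc(-c2ccc3cccc(F)c3c2)[nH]c1=O`: < 0.0667 h (a limit of the assay)

Compound 3 stands at the short end of the half-life values. Its < 0.0667 h is a limit and not a number.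

The next change leads to compound 4 `CC(C)C(/C=C1\CCNC1=O)c1ccc(-c2ccc3cccc(F)c3c2)[nH]c1=O`: a group of 7 heavy atoms (5 carbon, 1 nitrogen, 1 oxygen; one five-membered non-aromatic ring with 1 hetero atom) in place of a group of 5 heavy atoms (3 carbon, 2 nitrogen; one five-membered aromatic ring with 2 hetero atoms), on a saturated chain carbon bound to an aromatic carbon and a saturated chain carbon. The 1H-imidazol-2-yl group leaves, and the entering group has a non-aromatic ring.

Three measured steps at this same place bear on it. Two are large: an at least 42-fold higher number from compound 1 to compound 2 (1.63 log units; beyond the scatter), and an at least 44-fold lower number from compound 2 to compound 3 (1.65 log units; beyond the scatter). The third is an at least 1.0-fold lower number from compound 1 to compound 3 (0.02 log units; that floor lies within the scatter). Compound 2 goes against the short half-lives of the other two, and the group entering compound 4 is not the one it carries. The non-aromatic ring of compound 1 gave 0.07 h, so compound 4 is expected to stay near that end of this assay.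

The expected change is an at least 1.4-fold higher number from compound 3 to compound 4 (0.17 log units; that floor lies within the scatter), with no step beyond the scatter anticipated. For compound 4 the estimated half-life is 0.1 h, with an expected range from 0.05 h to 0.5 h.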

Compound 4, half-life: 0.345 h
The estimate for compound 4 lay 3.5-fold (0.54 log units) below the measured number; low and high end bracket the measured number.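

In this assay, a non-aromatic ring at this place does not by itself hold the half-life at the short end, as the step is a 4.9-fold higher number from compound 1 to compound 4 (0.69 log units; beyond the scatter). Against the 1H-imidazol-2-yl group the step is an at least 5.1-fold higher number from compound 3 to compound 4 (0.71 log units; beyond the scatter), which rests on a limit held by compound 3 and not on a number. The entering group still stays well short of the other extreme, with an at least 8.6-fold lower number from compound 2 to compound 4 (0.93 log units; beyond the scatter), and this step also rests on a limit, held by compound 2.

The ring and the double bonds outside aromatic rings enter together in compound 4, and the compounds shown do not separate them. Also open, going by these compounds, is how a carboxylic acid or an amine on this saturated chain carbon would stand in this assay.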